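Urea aryl swaps and fibroblast cytotoxicity in the series

The source may report more compounds than this note shows. Statements on the series, on what has been measured and on what is new or still open speak of the compounds shown alone.

Compound 2 `CCN(CC)CCn1cnnc1-c1cc(Oc2ccc(NC(=O)Nc3ccc(F)c(Cl)c3)cc2F)ccn1` gives 28700 nM in an ADME assay on WI-38 cells (Homo sapiens) for cytotoxicity, read by MTT assay, with a stated time of 72 h; on this read-out higher numbers stand for weaker inhibition and lower numbers for stronger inhibition. Among the two numbers so far it carries the highest value, with compound 1 `CCN(CC)CCn1cnnc1-c1cc(Oc2ccc(NC(=O)Nc3ccccc3C(F)(F)F)cc2F)ccn1` the nearest at 23500 nM, and the pair lies within the scatter of each other. Compound 3 `CCN(CC)CCn1cnnc1-c1cc(Oc2ccc(NC(=O)Nc3ccc(Cl)cc3Cl)cc2F)ccn1` has not yet been measured in this assay. It differs from compound 2 by 2,4-dichlorophenyl in place of 3-chloro-4-fluorophenyl on an amide-type nitrogen. Among the compounds with values here, the single measured step that bears on this place is the earlier aryl exchange on the same amide-type nitrogen, a 1.2-fold higher number from compound 1 to compound 2 (0.09 log units; within the scatter), which stayed within the scatter. With only that to go on, a further aryl exchange at the same position is expected to give no step beyond the scatter in this assay. The estimated step is accordingly a 1.0-fold lower number from compound 2 to compound 3 (0.01 log units; within the scatter). Compound 3 is therefore expected at about 28000 nM, with a range from 12000 nM to 65000 nM.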

Compound 3, half-maximal inhibitory concentration: 4280 nM
Beside the measured number, compound 3's estimate is 6.5-fold (0.82 log units) above it; measured number below the stated range.
By their numbers in this assay, from the lowest: compound 3; then compounds 1 and 2 (each within the scatter of the next).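

The aryl group on this amide-type nitrogen is not interchangeable in this assay (a 6.7-fold lower number from compound 2 to compound 3 (0.83 log units; beyond the scatter); a 5.5-fold lower number from compound 1 to compound 3 (0.74 log units; beyond the scatter)). Earlier, the exchange between 2-(trifluoromethyl)phenyl and 3-chloro-4-fluorophenyl had stayed within the scatter (a 1.2-fold higher number from compound 1 to compound 2 (0.09 log units; within the scatter)), so the position looked flat; with 2,4-dichlorophenyl, compound 3 now stands apart from both at the more cytotoxic end of the three. No measurement at hand accounts for this difference between aryl groups of equal heavy-atom count.

The compounds shown do not separate the contributions of the two chlorines, so how 2-chlorophenyl, 4-chlorophenyl or unsubstituted phenyl would read on this nitrogen stays open. Also open, as far as these compounds go, is whether the step holds when the diethylamino end of the shared core is replaced by a morpholine or a carboxylic acid.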